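The source may report more compounds than this note shows. Statements on the series, on what has been measured and on what is new or still open speak of the compounds shown alone.

Of the compounds shown here, two have so far been tested in a functional assay (Homo sapiens) for inhibition of Nucleic Acid, tested at 100 uM; on this read-out higher numbers stand for more inhibition at the one concentration tested (going by the name of the read-out) and lower numbers for less inhibition. Compound 1, with the structure `Clc1[nH]ccc2ncnc1-2`, gives 6% in this assay. Compound 2, with the structure `[O-][n+]1ccc2c(c1)ncn2C1O[C@H](CO)[C@@H](O)[C@H]1O`, gives 5% in this assay. These two numbers lie within the usual scatter of each other, so neither compound can be said to inhibit more than the other; both show little inhibition at the single concentration tested.

Compound 3, with the structure `Nc1[nH]ccc2ncnc1-2`, has not yet been measured in this assay. It differs from compound 1 in one place: amino in place of chloro on an aromatic carbon. Among the measured compounds shown here, no pair of measured compounds differing in one place is available, so the size of the effect of such a change on this read-out is unknown. Given that compound 1 gives 6% and compound 2 gives 5%, the step of a number 2 percentage points higher from compound 1 to compound 3 (within the scatter) is expected to be small and not beyond the scatter, in either direction. Compound 3 is therefore estimated to give 8% in this assay, with a range from 0% to 25%.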

Compound 3, a percentage reported as inhibition, at one concentration (the size of the read-out at that concentration, not a potency): 60%
Beside the measured number, compound 3's estimate is 52 percentage points below it; the measured number lies above the stated range.
By their numbers in this assay, from the lowest: compounds 2 and 1 (each within the scatter of the next); then compound 3.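

Among the compounds shown here, exchanging chloro for amino on this aromatic carbon, next to the ring nitrogen, gives a number 54 percentage points higher from compound 1 to compound 3 (beyond the scatter) in this assay, the first step between two compounds that differ in one place. This shows that the position is sensitive to what sits on it: with the rest of the core unchanged, replacing one heavy atom separates little inhibition from clear inhibition at the one concentration tested. The change swaps a chlorine for a nitrogen and adds a hydrogen-bond donor and a hydrogen-bond acceptor, but nothing measured here shows which of these differences, if any, accounts for the rise.

Going by these compounds, with a single step at a single position, it remains open whether the higher number is specific to amino or would also appear with a hydroxyl, a methyl or a methylamino group on the same aromatic carbon. A percentage at one concentration is also not a potency, so how compound 3 behaves at other concentrations remains an open question.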